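Series notes: amide-to-sulfonamide swap on the anilide core

This account rests on a few compounds, and the source may have more. Where it says the series, first, only, none or still open, it means among the compounds named here.

Measured compounds in an assay on isolated protein for inhibition of Rho-associated protein kinase 1 (Homo sapiens), read by scintillation counting, radiometric assay and 33P incorporation, with a stated time of 40 min, in the presence of a further agent that is not named here; a lower number here means a stronger inhibitor, a higher number a weaker inhibitor:
- compound 1 `COc1ccc(OCC(=O)Nc2cccc(NC(=O)c3ccc(N(C)C)cc3)c2)cc1OC`: only a limit of the assay, > 10000 nM
- compound 2 `COc1ccc(OCC(=O)Nc2cccc(NC(=O)c3ccc(N(C)C)cc3)c2)cc1F`: 1820 nM
- compound 3 `O=C(COc1ccc2c(=O)ccoc2c1)Nc1cccc(NC(=O)c2ccc(F)cc2)c1`: 129 nM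

Compound 1 sits at the assay limit (the limit of > 10000 nM in this assay, at which 1 of the 3 values shown sits), so it gives no number. Compound 3 holds the lowest number of the two that are known; its nearest neighbour is compound 2, with a higher number, and the gap lies beyond the scatter.

Among the measured compounds shown here, the one measured step, an at least 5.4-fold lower number from compound 1 to compound 2 (0.73 log units; beyond the scatter), concerns a fluoro replacing a methoxy on the part of the molecule that carries the ether. Compound 4 `Cn1ccc(S(=O)(=O)Nc2cccc(NC(=O)COc3ccc4c(=O)ccoc4c3)c2)n1` differs from compound 3 at the other end: a group of 9 heavy atoms (4 carbon, 2 nitrogen, 2 oxygen, 1 sulfur; one five-membered aromatic ring with 2 hetero atoms) in place of a group of 9 heavy atoms (7 carbon, 1 oxygen, 1 fluorine; one six-membered aromatic ring of carbon only), on a nitrogen on an aromatic ring. That step does not bear on the same place, so it gives no direct guide to the size of this change. For the measured compounds named here, the carbonyl-linked six-membered ring of compound 3 is replaced by a sulfonyl-linked five-membered ring with two hetero atoms and more acceptors; with no measured precedent for such a swap, a weakening is the cautious expectation, though of uncertain size.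

Compound 4 is estimated at 1500 nM in this assay, in the range 250 nM to 9000 nM. This expected value means a step of a 12-fold higher number from compound 3 to compound 4 (1.07 log units; beyond the scatter), towards a weaker inhibitor.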

Compound 4, half-maximal inhibitory concentration: > 10000 nM
Compound 4: a limit, no number; the forecaster's own chance of this, stated with the estimate: 20%; middle value at least 6.6-fold (0.82 log units) away from the limit.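

In this assay, the end of the molecule carrying the nitrogen on an aromatic ring matters a great deal: putting the sulfonyl-linked five-membered aromatic ring in place of the (4-fluorophenyl)carbonyl group gives an at least 77-fold higher number from compound 3 to compound 4 (1.88 log units; beyond the scatter). Among the compounds shown here, the only earlier step concerned the end that carries the ether, so this is the first reading at this position, and it is a large step in the weaker direction. Compound 4 gives only a limit of the assay, not a number, so the full size of the loss stays unknown, and the series now holds a second such limit: the limit of > 10000 nM in this assay, at which 2 of the 4 values shown sit.

The change swaps the linking carbonyl and the ring together, so the compounds shown cannot separate the two. A 4-fluorophenylsulfonyl group or the same five-membered ring on a carbonyl would tell which part carries the loss.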